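The source may hold more compounds than are shown below. What is called first, only, known or untested is meant among the compounds shown, and "the series" means these compounds.

Compound 3 `CC1CCN(c2c(S(=O)(=O)c3ccc(F)c(F)c3)cnc3c(F)cccc23)CC1` gives in an assay on isolated protein for displacement of a labelled ligand from metabotropic glutamate receptor 5 (Homo sapiens), with a stated time of 60 min, tested at 1 uM (on this read-out higher numbers stand for more inhibition at the one concentration tested (going by the name of the read-out) and lower numbers for less inhibition), a value of 93%, the second highest of the three numbers measured, with compound 1 `CC1CCN(c2c(S(=O)(=O)c3cc(F)cc(F)c3)cnc3cc(Cl)ccc23)CC1` at 94% and compound 2 `CC1CCN(c2c(S(=O)(=O)c3ccc(Cl)cc3)cnc3cc(Cl)ccc23)CC1` at 91%, both within the scatter of it. Compound 4 `CC1CCN(c2c(S(=O)(=O)c3ccc(C#N)cc3)cnc3c(F)cccc23)CC1` differs from compound 3 in one place: 4-cyanophenyl in place of 3,4-difluorophenyl on a sulfonyl sulfur. Within the data shown here, only one measured step bears on such an exchange at the sulfonyl sulfur, and that step, a number 3 percentage points lower from compound 1 to compound 2 (within the scatter), stayed within the scatter. Compound 4 is therefore expected to stay high as well, with a number 5 percentage points lower from compound 3 to compound 4 (within the scatter) amounting to no step beyond the scatter, though a modest drop cannot be ruled out. Compound 4 is estimated at 88%, between 72% and 97%.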

Compound 4, a percentage reported as inhibition, at one concentration (the size of the read-out at that concentration, not a potency): 86%
For compound 4 the middle estimate is 2 percentage points above the measured one; low and high end bracket the measured number.
By their numbers in this assay, from the lowest: compounds 4, 2, 3 and 1 (each within the scatter of the next).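

In this assay there is a number 7 percentage points lower from compound 3 to compound 4 (within the scatter) with 4-cyanophenyl on a sulfonyl sulfur, so an aryl group carrying a nitrile and a hydrogen-bond acceptor is accepted here, with no step beyond the scatter. This extends the earlier picture from two halogenated phenyl groups on the core of compound 1 to a non-halogenated one on the core of compound 3. Nothing available explains this result. Going by these compounds, whether an amine, a carboxylic acid or a longer alkyl chain on a sulfonyl sulfur would keep the number this high remains open.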